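Opening the Ring on a Tertiary Amide

The source may report more compounds than this note shows. Statements on the series, on what has been measured and on what is new or still open speak of the compounds shown alone.

Measured compounds:
Compound 1 `O=C(/C=C1\CCc2ccc(F)cc21)NCCO` gives 50%
Compound 2 `CC(C)NC(=O)/C=C1\CCc2ccc(F)cc21` gives 100%
Compound 3 `O=C(/C=C1\CCc2ccc(F)cc21)N1CCCC1` gives 33%

The three share one core and differ only in the group on the carbonyl carbon. In a functional assay on the whole organism with Mus musculus as the target, at a dose of 100 mg/kg by the intraperitoneal route (on this read-out lower numbers stand for less inhibition and higher numbers for more inhibition at the one dose given (going by the name of the read-out)), compound 3 stands lowest of the three: a number 17 percentage points lower from compound 1 to compound 3 (beyond the scatter) and a number 67 percentage points lower from compound 2 to compound 3 (beyond the scatter). Compound 4 `CCN(C)C(=O)/C=C1\CCc2ccc(F)cc21` has not been measured; (ethyl(methyl)amino in place of pyrrolidin-1-yl on a carbonyl carbon). Both measured steps ending at compound 3 replaced a group with a hydrogen-bond donor by one with none and both lowered the number, so they give little guidance for a change between two groups that each carry no donor. A step within the scatter is therefore expected, a number 5 percentage points higher from compound 3 to compound 4 (within the scatter). Compound 4 is estimated at 38%, with a range from 15% to 65%.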

Compound 4, a percentage reported as inhibition, in the whole organism at one dose (the size of the read-out at that dose, not a potency): 100%
Beside the measured number, compound 4's estimate is 62 percentage points below it; measured number above the stated range.
By their numbers in this assay, from the lowest: compound 3; then compound 1; then compounds 2 and 4 (each within the scatter of the next).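

Opening the ring in this assay gives a number 67 percentage points higher from compound 3 to compound 4 (beyond the scatter), so a tertiary amide at this carbonyl carbon can reach the top of this series without the amide hydrogen. Ethyl(methyl)amino in place of isopropylamino gives no change at the digits printed from compound 2 to compound 4 (within the scatter), and in place of (2-hydroxyethyl)amino it gives a number 50 percentage points higher from compound 1 to compound 4 (beyond the scatter). The low number of compound 3 therefore goes with the pyrrolidin-1-yl ring rather than with the missing hydrogen-bond donor alone.

As far as these compounds go, whether piperidin-1-yl, morpholin-4-yl or dimethylamino would fall with compound 3 or compound 4 stays open. No available evidence explains the gap between the ring and the open chain.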